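Extending an Ester Chain: From Compound 2 to Compound 3

The source may report more compounds than this note shows. Statements on the series, on what has been measured and on what is new or still open speak of the compounds shown alone.

Compound 1 `CC(=O)O[C@H]1C(=O)OCC1(C)C`: 33200 nM
Compound 2 `CCCC(=O)O[C@H]1C(=O)OCC1(C)C`: 28200 nM

Both numbers come from an assay on isolated protein for inhibition of fatty acid synthase (Mus musculus), read by spectrophotometry, using NADPH, with stated times of 30 min and 3 min, in the presence of a further agent that is not named here; a higher number here means a weaker inhibitor, a lower number a stronger inhibitor. The two compounds share one core and differ only in the length of the ester chain. Compound 2 and compound 1 sit within the scatter of each other: a 1.2-fold lower number from compound 1 to compound 2 (0.07 log units; within the scatter). That step was ethyl in place of hydrogen on a saturated chain carbon bound to a carbonyl carbon.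

Compound 3 `CCCCCC(=O)O[C@H]1C(=O)OCC1(C)C` carries the change (ethyl in place of hydrogen on a saturated chain carbon, three bonds along the chain from a carbonyl carbon). Among the compounds with values here, the only measured step that bears on it is the one from compound 1 to compound 2, which added the same ethyl group to the same chain and stayed within the scatter. A second addition of this kind is therefore expected to move this assay by little; the expected step is a 1.3-fold lower number from compound 2 to compound 3 (0.11 log units; within the scatter), downward if at all. Compound 3 is estimated at 22000 nM, with a range from 9000 nM to 55000 nM.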

Compound 3, half-maximal inhibitory concentration: 23300 nM
For compound 3 the middle estimate is 1.1-fold (0.02 log units) below the measured one, and the stated range covers the measured number.
By their numbers in this assay, from the lowest: compounds 3, 2 and 1 (each within the scatter of the next).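

The new point in this assay is that a second ethyl addition at this chain position (a 1.2-fold lower number from compound 2 to compound 3 (0.08 log units; within the scatter)) is also within the scatter. The full change across both additions (a 1.4-fold lower number from compound 1 to compound 3 (0.15 log units; within the scatter)) is within the scatter as well, so the two additions taken together do not add up to a measurable step. No measurement here gives a reason for this result.

Going by these compounds, what remains open is whether a still longer chain, or a chain carrying an amine or a carboxylic acid, would produce a step beyond the scatter. The three compounds also leave open whether a change to the shared core would matter more than any change to the ester chain.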